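Methyl for fluoro on the triazole phenyl, second core

The source may report more compounds than this note shows. Statements on the series, on what has been measured and on what is new or still open speak of the compounds shown alone.

Compound 1 `COc1cc2c(Oc3ccc(NC(=O)c4cn(-c5ccccc5F)nn4)cc3F)ccnc2cc1OCCCN1CCC(C)CC1` in a functional assay on HT-29 cells (Homo sapiens) for cytotoxicity, read by MTT assay, with a stated time of 72 h (on this read-out higher numbers stand for weaker inhibition and lower numbers for stronger inhibition), gives 210 nM. Compound 2 `COc1cc2c(Oc3ccc(NC(=O)c4cn(-c5ccccc5C)nn4)cc3F)ccnc2cc1OCCCN1CCC(C)CC1` gives 2380 nM in this assay, which is an 11-fold higher number from compound 1 to compound 2 (1.05 log units; beyond the scatter) for the change (methyl in place of fluoro on an aromatic carbon). Compound 3 `COc1cc2c(Oc3ccc(NC(=O)c4cn(-c5ccccc5F)nn4)cc3F)ccnc2cc1OCCCN1CCN(C)CC1` gives 300 nM in this assay; it differs from compound 1 by 4-methylpiperazin-1-yl in place of 4-methylpiperidin-1-yl on a saturated chain carbon, three bonds along the chain from an oxygen on an aromatic ring, and the step is a 1.4-fold higher number from compound 1 to compound 3 (0.15 log units; within the scatter). Compound 4 `COc1cc2c(Oc3ccc(NC(=O)c4cn(-c5ccccc5C)nn4)cc3F)ccnc2cc1OCCCN1CCN(C)CC1` is not yet measured; it differs from compound 3 by methyl in place of fluoro on an aromatic carbon, the same change made from compound 1 to compound 2, at a place described in the same words. The step from compound 3 to compound 4 is expected to be about a 10-fold higher number from compound 3 to compound 4 (1.00 log units; beyond the scatter), resting on the step of an 11-fold higher number from compound 1 to compound 2 (1.05 log units; beyond the scatter) and on the step of a 1.4-fold higher number from compound 1 to compound 3 (0.15 log units; within the scatter), which places compound 3 near compound 1. Compound 4 is therefore estimated at 3000 nM in this assay, plausibly between 1000 nM and 9000 nM.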

Compound 4, half-maximal inhibitory concentration: 1430 nM
The estimate for compound 4 lay 2.1-fold (0.32 log units) above the measured number, within the range that was stated.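

In this assay, 2-methylphenyl in place of 2-fluorophenyl gives a 4.8-fold higher number from compound 3 to compound 4 (0.68 log units; beyond the scatter), the same direction as on the core of compound 1, so the change carries across these two cores: the same change on two cores in this assay, an 11-fold higher number (1.05 log units; beyond the scatter) from compound 1 to compound 2 and a 4.8-fold higher number (0.68 log units; beyond the scatter) from compound 3 to compound 4, 2.4-fold (0.38 log units) apart, within the scatter of two such steps. The swap of 4-methylpiperidin-1-yl for 4-methylpiperazin-1-yl gives a 1.7-fold lower number from compound 2 to compound 4 (0.22 log units; within the scatter), and it also stays within the scatter with either aryl group: the same change on two cores in this assay, a 1.4-fold higher number (0.15 log units; within the scatter) from compound 1 to compound 3 and a 1.7-fold lower number (0.22 log units; within the scatter) from compound 2 to compound 4, 2.4-fold (0.38 log units) apart, within the scatter of two such steps. Among these compounds, these are only two pairs in one cell assay, so they do not show a fixed step size, a cause, or any behaviour on other cores.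

Still open, as far as these compounds go, is whether chloro or methoxy in place of the fluoro follows the same trend. Also open, from the compounds shown here alone, is whether morpholin-4-yl in place of 4-methylpiperazin-1-yl leaves the methyl-for-fluoro step intact.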